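The source may hold more compounds than are shown below. What is called first, only, known or untested is meant among the compounds shown, and "the series" means these compounds.

In a functional assay on Chorioallantoic membrane (Gallus gallus, strain Leghorn), read by microscopy, with a stated time of 40 h (a lower number here means a stronger inhibitor, a higher number a weaker inhibitor), compound 1 `COc1ccc(N(C)c2ncnc3occ(C)c23)cc1` gives 80 nM and compound 2 `CSc1ccc(N(C)c2ncnc3occ(C)c23)cc1` gives 520 nM which is the higher of the two numbers. Compound 3 `CNc1ccc(N(C)c2ncnc3occ(C)c23)cc1` differs from compound 2 in one place: methylamino in place of methylsulfanyl on an aromatic carbon with methylamino in place of methylsulfanyl on an aromatic carbon. Among the measured compounds shown here, the only measured step that bears on this is a 6.5-fold higher number from compound 1 to compound 2 (0.81 log units; beyond the scatter) which is modest and swaps methoxy for methylsulfanyl. For the measured compounds named here, no compound with methylamino has been measured yet, so this step is only a loose guide, but a smaller move towards a lower number is expected in this assay for compound 3. The expected step is a 2.6-fold lower number from compound 2 to compound 3 (0.41 log units; beyond the scatter) as estimated from that single comparison. Compound 3 is estimated at 200 nM with an expected range of 50 nM to 800 nM in this measurement.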

Compound 3, half-maximal inhibitory concentration: 707 nM
Estimate against measurement, compound 3: 3.5-fold (0.55 log units) below; the measured number falls inside the stated range.
By their numbers in this assay, from the lowest: compound 1; then compounds 2 and 3 (each within the scatter of the next).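

In this assay methylamino and methylsulfanyl on this aromatic carbon cannot be told apart, with a 1.4-fold higher number from compound 2 to compound 3 (0.13 log units; within the scatter) as the step between them. Methoxy does stand apart from methylamino, which gives an 8.8-fold higher number from compound 1 to compound 3 (0.95 log units; beyond the scatter) as a clear step, so among these three groups methoxy alone gives a distinctly lower number. Nothing measured here gives a reason for this.

Still open, going by these compounds, is whether ethoxy, a longer chain on the same oxygen, would keep the number close to that of compound 1. On these data alone, whether a hydroxyl or dimethylamino group on this carbon would do so is equally open.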